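The source may hold more compounds than are shown below. What is called first, only, known or untested is meant among the compounds shown, and "the series" means these compounds.

The measured compounds in a functional assay on CHO cells for agonist activity at adenosine receptor A1 (Homo sapiens), read by fluorescence and ERK phosphorylation, with stated times of 30 min and 1.5 h, tested at 3 uM; a lower number here means a weaker effect, a higher number a stronger effect of the compound at the concentration tested:

compound 1, `Nc1scc(-c2ccccc2)c1C(=O)c1ccccc1`, gives 49%
compound 2, `Nc1scc(-c2ccccc2F)c1C(=O)c1ccccc1`, gives 55%
compound 3, `Nc1scc(-c2ccc(F)cc2)c1C(=O)c1ccccc1`, gives 51%

Compound 3 stands second highest of these three numbers, yet all three lie within the scatter of one another: a number 2 percentage points higher from compound 1 to compound 3 (within the scatter) and a number 4 percentage points lower from compound 2 to compound 3 (within the scatter), as does a number 6 percentage points higher from compound 1 to compound 2 (within the scatter). Nothing separates them beyond the noise of the measurement.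

Compound 4, `Nc1scc(-c2ccc(I)cc2)c1C(=O)c1ccccc1`, differs from compound 3 by one change: iodo in place of fluoro on an aromatic carbon. Within the data shown here, no measured step exchanges one halogen for another; the steps at hand only put fluoro in place of hydrogen or move the fluoro on the same ring, and each of them stayed within the scatter. On that basis the step from compound 3 to compound 4 is expected to stay within the scatter as well, a number 1 percentage points higher from compound 3 to compound 4 (within the scatter), with no direction that the data would support. Compound 4 is therefore expected to give about 52% in this assay, within a range from 35% to 68%.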

Compound 4, a percentage reported as activity, at one concentration (the size of the read-out at that concentration, not a potency): 51%
Beside the measured number, compound 4's estimate is 1 percentage points above it; the measured number falls inside the stated range.
By their numbers in this assay, from the lowest: compounds 1, 3, 4 and 2 (each within the scatter of the next).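

In this assay, among these compounds, the first exchange of one halogen for another at this place, para to a large group, gives no change at the digits printed from compound 3 to compound 4 (within the scatter) and so adds a size of halogen that the fluoro compounds could not test. Iodo in place of hydrogen reads the same way, with a number 2 percentage points higher from compound 1 to compound 4 (within the scatter) on the one side and a number 4 percentage points lower from compound 2 to compound 4 (within the scatter) on the other, so hydrogen, fluoro and iodo at this place are not told apart by the read-out at the concentration tested. No measurement at hand offers any account of this result.

Going by these compounds, whether a group of another kind at this place, such as an amine or a carboxylic acid, would move the read-out beyond the scatter stays open. The potency of these compounds also stays open, since only the size of the effect at one concentration is shown.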